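This account rests on a few compounds, and the source may have more. Where it says the series, first, only, none or still open, it means among the compounds named here.

Compound 1, `COc1ccccc1Oc1c(N)nc(-c2ccc(I)cc2)nc1Cl`: 5400 nM
Compound 2, `COc1ccccc1Oc1c(N)nc(-c2ccccc2)nc1OCCO`: 31100 nM

Among the compounds with values here, these are the only two compounds with numbers so far, both measured in a functional assay on B16 cells (Mus musculus) for cytotoxicity, read by CCK-8 assay, with a stated time of 24 h; on this read-out lower numbers stand for stronger inhibition and higher numbers for weaker inhibition. Compound 2 gives the higher of the two numbers, and compound 1, which differs from it in more than one place, gives a lower one; that gap lies beyond the usual scatter of the test. Compound 3, `COc1ccccc1Oc1c(N)nc(-c2ccc(Br)cc2)nc1OCCO`, has not yet been measured. It differs from compound 2 in one place only: bromo in place of hydrogen on an aromatic carbon. Because compound 1 gives 5400 nM and carries a halogen on the same ring, a step toward a lower number is expected, though compound 1 also differs elsewhere, so the size is uncertain. The estimated step is a 2.6-fold lower number from compound 2 to compound 3 (0.41 log units; beyond the scatter), toward stronger inhibition. Compound 3 is thus expected to give about 12000 nM, with a likely range from 4000 nM to 35000 nM.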

Compound 3, half-maximal inhibitory concentration: 11800 nM
Compound 3: the middle estimate sits 1.0-fold (0.01 log units) above what was measured; the range from low to high includes it.
By their numbers in this assay, from the lowest: compound 1; then compound 3; then compound 2.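

In this assay, within the data shown here, the change from phenyl to 4-bromophenyl gives a 2.6-fold lower number from compound 2 to compound 3 (0.42 log units; beyond the scatter), and this is the first comparison in which only one place differs. Compound 1 and compound 2 differ in more than one place, so their gap could not be tied to the ring alone; here, one bromine atom on an aromatic carbon, para to a large group, moves the number beyond the usual scatter, toward stronger inhibition, though the step is modest. Among these compounds, nothing measured so far explains this shift.

On these data alone, it remains open whether this step is particular to bromo or would also appear with fluoro, methoxy or an amine at the same place. Also open, as far as these compounds go, is whether the step would keep its size if other parts of the core changed.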